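Ester side-chain change from compound 3 to compound 4

The compounds below may be only part of what the source reports. "The series", "measured", "known", "first", "only" and "open" are said of these compounds alone.

Measured so far in an assay on membranes from brain for inhibition of Fatty-acid amide hydrolase 1 (Rattus norvegicus); on this read-out lower numbers stand for stronger inhibition and higher numbers for weaker inhibition:
- compound 1, `CCCCCCCCCCC[C@@H](C[C@@H]1OC(=O)[C@H]1CCCCCC)OC(=O)[C@H](CC(C)C)NC(=O)OC(C)(C)C`: compound 1 gives > 50000 nM, which is a limit of this assay.
- compound 2, `CCCCCCCCCCC[C@@H](C[C@@H]1OC(=O)[C@H]1CCCCCC)OC(=O)CCC(C)C`: compound 2 gives 10400 nM.
- compound 3, `CCCCCCCCCCC[C@@H](C[C@@H]1OC(=O)[C@H]1CCCCCC)OC(=O)CCNC=O`: compound 3 gives > 50000 nM, again a limit of this assay.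

Compound 3 therefore stands at the limit described in the limit of > 50000 nM in this assay, at which 2 of the 3 values shown sit; only compound 2 gives a number. The two measured steps run in opposite directions: an at least 4.8-fold lower number from compound 1 to compound 2 (0.68 log units; beyond the scatter), and an at least 4.8-fold higher number from compound 2 to compound 3 (0.68 log units; beyond the scatter). Both steps involve a nitrogen-containing substituent, and both compounds carrying one sit at the limit.

Compound 4, `CCCCCCCCCCC[C@@H](C[C@@H]1OC(=O)[C@H]1CCCCCC)OC(=O)[C@@H]1CCC(=O)N1`, differs from compound 3 by 5-oxopyrrolidin-2-yl in place of 2-(formylamino)ethyl on a carbonyl carbon. The incoming group keeps one hydrogen-bond donor and one hydrogen-bond acceptor, now held in a five-membered ring, so the change most resembles the variation between compound 2 and compound 3 rather than a return to a plain alkyl chain. A small step is expected in this assay, an at least 1.2-fold lower number from compound 3 to compound 4 (0.09 log units; that floor lies within the scatter), and the value may again be reported as a limit. Compound 4 is estimated at 40000 nM with a range of 8000 nM to 120000 nM.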

Compound 4, half-maximal inhibitory concentration: > 50000 nM
Compound 4: only a limit was reported (the forecaster's own chance of this, stated with the estimate: 60%); middle value at least 1.2-fold (0.09 log units) away from the limit.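

In this assay compound 4 gives > 50000 nM, which is a limit of the assay. Putting 5-oxopyrrolidin-2-yl in place of isopentyl on the carbonyl carbon gives an at least 4.8-fold higher number from compound 2 to compound 4 (0.68 log units; beyond the scatter), so the loss against the isopentyl ester is not confined to the open-chain 2-(formylamino)ethyl group and also appears with the five-membered non-aromatic ring. The step from compound 3 to compound 4 cannot be read, and all the nitrogen-bearing side chains shown, with no compound going against this, now sit at one limit: the limit of > 50000 nM in this assay, at which 3 of the 4 values shown sit.

For the compounds shown here, how compound 1, compound 3 and compound 4 rank among themselves stays unknown, and the only compound with a number, compound 2, gives 10400 nM, so the effect of the nitrogen cannot yet be separated from that of the chain or ring carrying it. On these data alone, whether cyclopentyl, a longer alkyl chain, an amine or a carboxylic acid on this carbonyl carbon would give a number in this assay remains open.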